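A few compounds are considered here, and "the series" means these few. Any claim that something is new, unique, unknown or untested is made for them only; others in the source may bear on it.

Of the compounds shown here, three sharing one core have been measured in a physicochemical assay for lipophilicity, measured as octanol-water partition, at pH 7.4; on this read-out lower numbers stand for lower lipophilicity and higher numbers for higher lipophilicity. Compound 1 `Clc1ccc(NC2=NCCC3(CCCCC3)S2)cc1` gives 2.5, compound 2 `FC(F)(F)c1ccc(NC2=NCCC3(CCCCC3)S2)cc1` gives 2.18, and compound 3 `COc1ccc(NC2=NCCC3(CCCCC3)S2)cc1` gives 0.8. Compound 3 stands lowest of the three: the nearest number is that of compound 2, as seen in the step of a number 1.38 log units lower from compound 2 to compound 3 (beyond the scatter), and the furthest is that of compound 1, as seen in the step of a number 1.70 log units lower from compound 1 to compound 3 (beyond the scatter). Both steps end at the methoxy compound and both are large, whereas the step of a number 0.32 log units lower from compound 1 to compound 2 (beyond the scatter) between the other two is modest.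

Compound 4 `CC(=O)c1ccc(NC2=NCCC3(CCCCC3)S2)cc1` differs from compound 3 in one place: acetyl in place of methoxy on an aromatic carbon. Going by the values given here, no measured step exchanges methoxy for acetyl, so the two large steps leading to compound 3 only show that replacing the methoxy group by chloro or trifluoromethyl moved this assay upward; they give no direct guide to acetyl. With two groups of comparable count of heavy atoms and the same count of acceptors exchanged, the step of a number 0.10 log units lower from compound 3 to compound 4 (within the scatter) is expected to be small, not beyond the scatter in either direction. Compound 4 is therefore estimated at 0.7, within a range from 0.1 to 1.4.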

Compound 4, distribution coefficient: 1.97
The estimate for compound 4 lay 1.27 log units below the measured number, outside the stated range (above it).
By their numbers in this assay, from the lowest: compound 3; then compounds 4 and 2 (each within the scatter of the next); then compound 1.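

In this assay, the exchange of methoxy for acetyl on an aromatic carbon para to a large group proves to be no minor change, with a number 1.17 log units higher from compound 3 to compound 4 (beyond the scatter), even though the two groups carry the same count of hydrogen-bond acceptors and neither has a net charge. The acetyl compound instead falls in with the trifluoromethyl and chloro compounds, with a number 0.21 log units lower from compound 2 to compound 4 (within the scatter) and a number 0.53 log units lower from compound 1 to compound 4 (beyond the scatter), so among these four compounds the methoxy compound alone stands far from the others, and the large gap is not confined to the exchange of methoxy for a halogen-bearing group. Nothing available explains why methoxy stands apart from the other three groups. The compounds shown leave open whether another group joined to the aromatic ring through oxygen, such as ethoxy or hydroxy, would stay close to compound 3, or whether an amine or a nitrile would join the upper group instead. They also leave open whether the gap between methoxy and acetyl would persist at another place on the aromatic ring or on a different core.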